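This account rests on a few compounds, and the source may have more. Where it says the series, first, only, none or still open, it means among the compounds named here.

Measured so far in this assay:
- compound 1, `C[C@H](NC(=O)Nc1ccccc1F)c1ccccc1`: 92%
- compound 2, `C[C@@H](NC(=O)Nc1ccccc1Cl)c1ccccc1`: 103%

Of the compounds shown here, two have been read in an ADME assay on the whole organism with Oryza sativa as the target, tested at 1 uM; on this read-out lower numbers stand for a stronger effect and higher numbers for a weaker effect at the one concentration tested. Compound 1 gives 92%, and compound 2 gives 103%. Compound 2 stands highest of the two numbers; its nearest neighbour is compound 1, which reads lower by a gap beyond the scatter. Compound 1 and compound 2 differ in more than one place, so their gap cannot be tied to a single structural change, and nothing more is drawn from it.

The next step goes from compound 2 to compound 3, `C[C@H](NC(=O)Nc1ccccc1Cl)c1ccccc1`, not yet measured in this assay. The change: the two compounds have the same atoms and bonds and differ only in configuration as drawn: 1 of 1 stereo elements differ; a stereocentre at a saturated chain carbon is drawn R in compound 2 and S in compound 3. Among the compounds with values here, no measured pair shows what such a change alone does on this read-out, so the direction is open. The working expectation is a small step, a number 6 percentage points lower from compound 2 to compound 3 (within the scatter), that stays within the scatter, with no firm lean toward a stronger or weaker effect. On that basis compound 3 is estimated at 97%, with a range from 80% to 112%.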

Compound 3, a percentage reported as activity, at one concentration (the size of the read-out at that concentration, not a potency): 104%
The estimate for compound 3 lay 7 percentage points below the measured number; the range from low to high includes it.
By their numbers in this assay, from the lowest: compound 1; then compounds 2 and 3 (each within the scatter of the next).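

In this assay, the switch of the stereocentre at the saturated chain carbon from R to S gives a number 1 percentage points higher from compound 2 to compound 3 (within the scatter), so with chloro on the aromatic carbon this pair shows no effect of the drawn configuration that can be told from the scatter. The pair isolates that single element, and the reading rests on this: the fact that compounds 2 and 3 differ only in the configuration as drawn The series also gains its first comparison that can be read for the halogen, with the configuration drawn the same in both compounds: chloro in place of fluoro on an aromatic carbon gives a number 12 percentage points higher from compound 1 to compound 3 (beyond the scatter), a modest step toward a weaker effect at the one concentration tested.

Going by these compounds, whether the stereocentre is equally silent with fluoro on the aromatic carbon remains open, as does whether the halogen step holds for the R configuration. Also open, on these data alone, is what a bromo or methoxy group on that aromatic carbon would give, and whether either would extend the step seen from fluoro to chloro or reverse it.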